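Cyano for isopropyl: from compound 3 to compound 4

A few compounds are considered here, and "the series" means these few. Any claim that something is new, unique, unknown or untested is made for them only; others in the source may bear on it.

In a functional assay on MES-SA cells (Homo sapiens) for cytotoxicity, read by luminescence and CellTiter-Glo, with a stated time of 72 h (a lower number here means a stronger inhibitor, a higher number a weaker inhibitor), compound 1 `CC[C@H](NC(=O)[C@H](COC)NC(=O)c1cc(C)on1)C(=O)N[C@@H](CC(C)C)C(=O)[C@@]1(C)CO1` gives 468 nM, compound 2 `COC[C@H](NC(=O)c1cc(C)on1)C(=O)N[C@@H](CC1CCCCC1)C(=O)N[C@@H](CC(C)C)C(=O)[C@@]1(C)CO1` gives 353 nM and compound 3 `COC[C@H](NC(=O)c1cc(C)on1)C(=O)N[C@@H](CC(C)C)C(=O)N[C@@H](CC(C)C)C(=O)[C@@]1(C)CO1` gives 366 nM. Compound 3 therefore stands within the scatter of both others. The next structure is compound 4 `COC[C@H](NC(=O)c1cc(C)on1)C(=O)N[C@@H](CC#N)C(=O)N[C@@H](CC(C)C)C(=O)[C@@]1(C)CO1`, with this difference: cyano in place of isopropyl on a saturated chain carbon, two bonds along the chain from an amide-type nitrogen and a carbonyl carbon. This places cyano in place of isopropyl on a saturated chain carbon, two bonds along the chain from an amide-type nitrogen and a carbonyl carbon. Cut one bond further out, the change reads isobutyl to cyanomethyl. Going by the values given here, three measured steps concern the same place: a 1.3-fold lower number from compound 1 to compound 3 (0.11 log units; within the scatter), a 1.3-fold lower number from compound 1 to compound 2 (0.12 log units; within the scatter) and a 1.0-fold higher number from compound 2 to compound 3 (0.02 log units; within the scatter). All three lie within the scatter, so methyl, isopropyl and cyclohexyl cannot be told apart here. From the compounds shown here alone, none of these steps introduces a cyano group, so this change remains untested and the range stays wide. A small step towards a higher number is expected in this assay, a 1.5-fold higher number from compound 3 to compound 4 (0.18 log units; within the scatter). The estimate for compound 4 is 550 nM, with an expected range of 220 nM to 1500 nM.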

Compound 4, half-maximal inhibitory concentration: 941 nM
Compound 4: middle estimate off by 1.7-fold (0.23 log units), on the low side, and the stated range covers the measured number.
By their numbers in this assay, from the lowest: compounds 2, 3, 1 and 4 (each within the scatter of the next, the first and the last beyond it).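

In this assay this position is no longer silent: a 2.6-fold higher number from compound 3 to compound 4 (0.41 log units; beyond the scatter) and a 2.7-fold higher number from compound 2 to compound 4 (0.43 log units; beyond the scatter) both lie beyond the scatter, whereas methyl, isopropyl and cyclohexyl could not be told apart. The separation is only partial, as a 2.0-fold higher number from compound 1 to compound 4 (0.30 log units; within the scatter) stays within the scatter, so cyano stands apart from isopropyl and cyclohexyl but not from methyl. No supporting measurement bears on the reason for these steps.

The compounds shown leave open whether the higher number belongs to the nitrile specifically or would also appear with other non-hydrocarbon groups at this place, such as an amine, a carboxylic acid or a primary amide. They also leave open whether a longer chain ending in a nitrile would read like cyanomethyl or like isobutyl.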